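Swapping the ethoxy group of compound 1

A few compounds are considered here, and "the series" means these few. Any claim that something is new, unique, unknown or untested is made for them only; others in the source may bear on it.

Measured compounds:
- Compound 1 `CCOC1c2cc(OCc3cc(C)cc(C)c3)c(OCc3cc(C)cc(C)c3)cc2CCN1C(=O)OC(C)(C)C`: > 20000 nM
- Compound 2 `CCC[C@@H]1C[C@@H](O)/C=C\C(CC)[C@H]2c3cc(OCc4ccccc4)c(OCc4ccccc4)cc3CCN12`: "not determined" (no result reported)

The study's data on these compounds come from an ADME assay on RWPE-1 cells (Homo sapiens) for inhibition, read by MTT assay, with a stated time of 24 h (a higher number here means a weaker inhibitor, a lower number a stronger inhibitor), and they are sparse. Compound 1 gives only a limit of the assay and not a number, > 20000 nM. Among the compounds with values here, compound 2 has no reported result, "not determined" (no result reported), so no step between measured compounds can be read.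

The next compound, compound 3 `C/C=C/C(=O)CC1c2cc(OCc3cc(C)cc(C)c3)c(OCc3cc(C)cc(C)c3)cc2CCN1C(=O)OC(C)(C)C`, keeps the core of compound 1 and changes it in one place. It carries ((prop-1-en-1-yl)carbonyl)methyl in place of ethoxy on a saturated ring carbon.

With compound 1 reported only as the limit > 20000 nM, the one move that could register in this assay is toward a stronger inhibitor. The expected change, an at least 1.3-fold lower number from compound 1 to compound 3 (0.12 log units; that floor lies within the scatter), is small and is expected to stay within the scatter, with a slight lean in that direction. A further reading at the limit would be no surprise. Compound 3 is estimated at 15000 nM, with an expected range of 5000 nM to 35000 nM.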

Compound 3, half-maximal inhibitory concentration: > 20000 nM
Compound 3 gave a limit, no number (the forecaster's own chance of this, stated with the estimate: 55%); middle value at least 1.3-fold (0.12 log units) from the limit.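

In this assay compound 3 gives > 20000 nM, a limit and not a number. Within the data shown here, compound 1 is also reported only as a limit, and no step between compound 1 and compound 3 can be read. The compounds shown leave open whether ((prop-1-en-1-yl)carbonyl)methyl in place of ethoxy changes inhibition at all.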